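From amino to bromo: compound 1 to compound 4

A few compounds are considered here, and "the series" means these few. Any claim that something is new, unique, unknown or untested is made for them only; others in the source may bear on it.

Going by the values given here, in a functional assay on the whole organism with Mus musculus as the target (on this read-out lower numbers stand for an effect already at smaller amounts and higher numbers for an effect only at larger amounts of compound), compound 1 (`COc1cc2c(cc1OC)C(c1ccc(N)cc1)=NN=C(S)C2`) gives (6.3 umol/kg), the lowest of the three numbers so far. Compound 2 (`COc1cc2c(cc1OC)C(c1ccc(Br)cc1)=NNC(=O)C2`) gives (110 umol/kg) and compound 3 (`COc1cc2c(cc1OC)C(c1ccc(Br)cc1)=NN(C)C(=S)C2`) gives (105 umol/kg). Both lie higher than compound 1 by more than the scatter, and they lie within the scatter of each other.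

Compound 4 (`COc1cc2c(cc1OC)C(c1ccc(Br)cc1)=NN=C(S)C2`) is still unmeasured. It has bromo in place of amino on an aromatic carbon, para to a large group, and the rest of compound 1 is unchanged. Among the compounds with values here, no measured pair isolates this change, so the direction can only be inferred. Compound 3 (105 umol/kg) and compound 2 (110 umol/kg) both carry the 4-bromophenyl group, though each differs from compound 4 elsewhere in the structure.

In this assay a step towards a higher number, beyond the scatter, is expected (a 6.3-fold higher number from compound 1 to compound 4 (0.80 log units; beyond the scatter)). For compound 4 the estimated value is (40 umol/kg), with an expected range from (14 umol/kg) to (115 umol/kg).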

Compound 4, dose for half-maximal effect: 52.1 umol/kg
Estimate against measurement, compound 4: 1.3-fold (0.11 log units) below; the range from low to high includes it.
By their numbers in this assay, from the lowest: compound 1; then compounds 4, 3 and 2 (each within the scatter of the next, the first and the last beyond it).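

With the rest of the structure unchanged, bromo in place of amino on an aromatic carbon, para to a large group, gives an 8.3-fold higher number from compound 1 to compound 4 (0.92 log units; beyond the scatter) in this assay. Going by these compounds alone, this is the first comparison that isolates a single place, and it shows that the read-out responds to the group at this position. Within this pair, the 4-aminophenyl group carries the lower number, and no measurement at hand accounts for the size or direction of the step.

Only amino and bromo are compared at this place, and the pair does not separate the loss of amino from the arrival of bromo. Open, as far as these compounds go, is how a hydroxy, methoxy, acetylamino or chloro group at the same aromatic carbon would read out.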